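Removing the Methylene Link in an Imidazolyl Side Chain

The compounds below may be only part of what the source reports. "The series", "measured", "known", "first", "only" and "open" are said of these compounds alone.

Of the compounds shown here, two that share a core have been measured in an ADME assay on microsomes from liver (Homo sapiens) for metabolic stability; a lower number here means that the compound disappears faster, a higher number that the compound lasts longer. Compound 1 `CC(C)C(Cc1ncc[nH]1)c1ccc(-c2ccc3cccc(F)c3c2)[nH]c1=O` gives 0.106 h and stands lowest of the two numbers. Its nearest neighbour, compound 2 `CCC(CC)(c1nnc[nH]1)c1ccc(-c2ccc3cccc(F)c3c2)[nH]c1=O`, gives 1.19 h, a higher value beyond the usual scatter; the two differ in more than one place, so their values are shown without a computed step. Compound 3 `CC(C)C(c1ncc[nH]1)c1ccc(-c2ccc3cccc(F)c3c2)[nH]c1=O` has not yet been measured. It differs from compound 1 in one place: 1H-imidazol-2-yl in place of (1H-imidazol-2-yl)methyl on a saturated chain carbon bound to an aromatic carbon and a saturated chain carbon. Among the compounds with values here, no step between measured compounds mirrors this change, so the expectation rests on the position of compound 1 alone. The author expects the change from compound 1 to compound 3 to shift the half-life upward only modestly, by a 1.7-fold higher number from compound 1 to compound 3 (0.23 log units; within the scatter), close to the edge of the scatter. On that basis compound 3 is estimated at 0.18 h, with a range from 0.07 h to 0.5 h.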

Compound 3, half-life: < 0.0667 h
Compound 3: a limit, no number (the forecaster's own chance of this, stated with the estimate: 5%); middle value at least 2.6-fold (0.43 log units) away from the limit.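

In this assay, compound 3 carries no number, only a limit of the assay: the limit of < 0.0667 h in this assay, at which 1 of the 3 values shown sits. This is the first change in one place among the compounds shown, and on the saturated chain carbon, 1H-imidazol-2-yl in place of (1H-imidazol-2-yl)methyl gives an at least 1.5-fold lower number from compound 1 to compound 3 (0.20 log units; that floor lies within the scatter). The shorter attachment therefore brings no gain in half-life here, but the floor of the step alone does not establish a loss beyond the scatter.

From the compounds shown here alone, how far the true half-life of compound 3 lies past the limit remains open, and so does the full size of the step. Also open, going by these compounds, is how a longer chain carrying the imidazole, or an amine or a carboxylic acid in its place on this carbon, would behave in this assay.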